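A Hydrogen for Benzyloxycarbonyl on a Ring Nitrogen

The source may report more compounds than this note shows. Statements on the series, on what has been measured and on what is new or still open speak of the compounds shown alone.

In a functional assay on PC-3 cells (Homo sapiens) for inhibition, read by MTT assay, with a stated time of 72 h (on this read-out lower numbers stand for stronger inhibition and higher numbers for weaker inhibition), compound 1 `O=C(OCc1ccccc1)N1CCN(C(=S)SCc2cn(Cc3ccccc3F)nn2)CC1` gives 68300 nM, and compound 2 `Fc1ccccc1Cn1cc(CSC(=S)N2CCNCC2)nn1` gives 56200 nM. The change between them is hydrogen in place of benzyloxycarbonyl on an amine nitrogen in a ring, and the step of a 1.2-fold lower number from compound 1 to compound 2 (0.08 log units; within the scatter) is small. Compound 3 `COc1cc(Cn2cc(CSC(=S)N3CCN(C(=O)OCc4ccccc4)CC3)nn2)cc(OC)c1OC` carries a different core, which differs from that of compound 1 by 3,4,5-trimethoxyphenyl in place of 2-fluorophenyl on a saturated chain carbon bound to an aromatic nitrogen. For compound 3 this assay reports only a limit, > 128000 nM, as noted in the limit of > 128000 nM in this assay, at which 1 of the 3 values shown sits. Compound 4 `COc1cc(Cn2cc(CSC(=S)N3CCNCC3)nn2)cc(OC)c1OC`, not yet measured, differs from compound 3 by hydrogen in place of benzyloxycarbonyl on an amine nitrogen in a ring, the same change that separates compound 1 from compound 2. The step that the limit leaves unreadable from compound 3 to compound 4 is expected to be small, resting on the step of a 1.2-fold lower number from compound 1 to compound 2 (0.08 log units; within the scatter) seen with compound 1 and compound 2. Compound 4 is therefore estimated at 150000 nM in this assay, within 70000 nM to 400000 nM, and it may again be reported only as a limit.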

Compound 4, half-maximal inhibitory concentration: > 128000 nM
Compound 4 ended at the assay's limit; the forecaster's own chance of this, stated with the estimate: 60%; the middle value is on the limit's open side.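

Compound 4 gives > 128000 nM in this assay, which is a limit and not a number, so no step from compound 3 to compound 4 can be read: the limit of > 128000 nM in this assay, at which 2 of the 4 values shown sit.

The compounds shown leave open whether hydrogen in place of benzyloxycarbonyl changes the number when 3,4,5-trimethoxyphenyl stands in place of 2-fluorophenyl.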